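From Dichlorophenyl to Thiophenyl: A Small Step Expected

This account rests on a few compounds, and the source may have more. Where it says the series, first, only, none or still open, it means among the compounds named here.

Of the compounds shown here, two have been measured in an ADME assay on SH-SY5Y cells (Homo sapiens) for inhibition, read by MTT assay, with a stated time of 72 h, tested at 50 uM; on this read-out higher numbers stand for more inhibition at the one concentration tested (going by the name of the read-out) and lower numbers for less inhibition. Compound 1 `COc1cc(OC)c(Cc2coc3cc(O)cc(O)c3c2=O)c(OC)c1` gives 15.3%, and compound 2 `COc1cc(OC)c2c(=O)c(Cc3ccc(Cl)c(Cl)c3)coc2c1` gives 21.6% in this assay. These two numbers lie within the scatter of each other, so compound 2 cannot be ranked against compound 1. Compound 3 `COc1cc(OC)c2c(=O)c(Cc3cccs3)coc2c1` awaits measurement and differs from compound 2 in one place: thiophen-2-yl in place of 3,4-dichlorophenyl on a saturated chain carbon bound to an aromatic carbon. Going by the values given here, with no step between measured compounds known, the expected step of a number 4.6 percentage points lower from compound 2 to compound 3 (within the scatter) in this assay is small, slightly downward, and not beyond the scatter. Compound 3 is therefore estimated at 17%, within a range from 5% to 32%.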

Compound 3, a percentage reported as inhibition, at one concentration (the size of the read-out at that concentration, not a potency): 19%
The estimate for compound 3 lay 2 percentage points below the measured number; the range from low to high includes it.
By their numbers in this assay, from the lowest: compounds 1, 3 and 2 (each within the scatter of the next).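

In this assay, thiophen-2-yl in place of 3,4-dichlorophenyl on a saturated chain carbon bound to an aromatic carbon gives a number 2.6 percentage points lower from compound 2 to compound 3 (within the scatter) as the first step read at this position. The read-out thus does not separate these two aromatic rings, so neither the chlorine atoms nor the six-membered ring of carbon is needed for a number of this size in this pair. Nothing shown accounts for this result. Still open, going by these compounds, is how an amine, a carboxylic acid or a longer chain in place of the aromatic ring at this position would read in this assay.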